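Pyridinyl to fluorophenyl on the triazole of two diterpenoid cores

The source may hold more compounds than are shown below. What is called first, only, known or untested is meant among the compounds shown, and "the series" means these compounds.

In a functional assay on MCF7 cells (Homo sapiens) for cytotoxicity, read by MTT assay, with a stated time of 4 days (a lower number here means a stronger inhibitor, a higher number a weaker inhibitor), compound 2 `C=C1C(=O)[C@]23C[C@@]1(O)CC[C@H]2c1ccc(O)c(C)c1[C@@H]3Cn1cc(-c2ccccn2)nn1` gives 2240 nM. Compound 3 `Cc1c(O)ccc2c1[C@H](Cn1cc(-c3ccccn3)nn1)[C@@]13CC(=O)[C@@](C)(CC[C@@H]21)C3` reaches only the limit of this assay, > 20000 nM. Compound 1 `Cc1c(O)ccc2c1[C@H](Cn1cc(-c3ccc(F)cc3)nn1)[C@@]13CC(=O)[C@@](C)(CC[C@@H]21)C3` likewise reaches only the limit, > 20000 nM. The step that the two limits leave unreadable from compound 3 to compound 1 is made by 4-fluorophenyl in place of pyridin-2-yl on an aromatic carbon and its size cannot be read, because both ends sit at the limit of > 20000 nM in this assay, at which 2 of the 3 values shown sit. How the core of compound 2 differs from the core of compound 3 is not broken down here. Compound 4 `C=C1C(=O)[C@]23C[C@@]1(O)CC[C@H]2c1ccc(O)c(C)c1[C@@H]3Cn1cc(-c2ccc(F)cc2)nn1` carries the same change on the core of compound 2, (4-fluorophenyl in place of pyridin-2-yl on an aromatic carbon). Since the measured instance gives no size, the expected step of a 1.1-fold higher number from compound 2 to compound 4 (0.05 log units; within the scatter) is taken as small. Compound 4 is therefore estimated at 2500 nM in this assay, between 700 nM and 9000 nM.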

Compound 4, half-maximal inhibitory concentration: 1700 nM
Beside the measured number, compound 4's estimate is 1.5-fold (0.17 log units) above it; the range from low to high includes it.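

On the core of compound 2, 4-fluorophenyl in place of pyridin-2-yl gives a 1.3-fold lower number from compound 2 to compound 4 (0.12 log units; within the scatter) in this assay, so on this core the exchange leaves no readable difference between the two compounds. The matching step on the core of compound 3 cannot be read, since compound 3 and compound 1 each give only a limit and not a number: the limit of > 20000 nM in this assay, at which 2 of the 4 values shown sit. This single readable pair therefore does not show that the change behaves alike on both cores.

Going by these compounds, it remains open whether an amine, a carboxylic acid or a longer alkyl chain on that aromatic carbon would leave the number unchanged on the core of compound 2. On these data alone, it is also open whether any such group would bring the core of compound 3 off the limit.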